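The source may report more compounds than this note shows. Statements on the series, on what has been measured and on what is new or still open speak of the compounds shown alone.

Measured so far in a toxicity assay on HaCaT cells (Homo sapiens) for cytotoxicity, read by CCK-8 assay, with a stated time of 24 h (a higher number here means that more compound is tolerated, a lower number that less compound is tolerated), as read-out:
- compound 1 `COc1ccccc1Oc1c(N)nc(-c2ccc(F)cc2)nc1Cl` gives 42600 nM
- compound 2 `COc1ccccc1Oc1c(N)nc(-c2ccc(C)cc2)nc1OCCO` gives 56600 nM
- compound 3 `COc1cccc(-c2nc(N)c(Oc3ccccc3OC)c(OCCO)n2)c1` gives 12700 nM

Compound 3 holds the lowest of the three numbers, with compound 1 nearest. Compound 4 `COc1ccccc1Oc1c(N)nc(-c2ccc(F)cc2)nc1OCCO` has 4-fluorophenyl in place of 3-methoxyphenyl on an aromatic carbon between two ring nitrogen atoms 4-fluorophenyl in place of 3-methoxyphenyl on an aromatic carbon and otherwise matches compound 3. Within the data shown here, one measured step bears directly on this place: a 4.5-fold lower number from compound 2 to compound 3 (0.65 log units; beyond the scatter) as 3-methoxyphenyl replaced 4-methylphenyl. Compound 1 also carries 4-fluorophenyl and gives 42600 nM on a core that differs elsewhere. A step of similar size towards a higher number is therefore expected in this assay. The estimated move is a 3.5-fold higher number from compound 3 to compound 4 (0.55 log units; beyond the scatter) and lies beyond the scatter. Compound 4 is expected at 45000 nM (range 21000 nM to 95000 nM).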

Compound 4, half-maximal cytotoxic concentration: 15100 nM
Estimate against measurement, compound 4: 3.0-fold (0.47 log units) above, and the stated range ends above it.
By their numbers in this assay, from the lowest: compounds 3 and 4 (each within the scatter of the next); then compounds 1 and 2 (each within the scatter of the next).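

In this assay, 4-fluorophenyl and 3-methoxyphenyl on the aromatic carbon between two ring nitrogen atoms are not separated (a 1.2-fold higher number from compound 3 to compound 4 (0.08 log units; within the scatter)), so among the 2-hydroxyethoxy compounds only the 4-methylphenyl of compound 2 stands apart (a 3.7-fold lower number from compound 2 to compound 4 (0.57 log units; beyond the scatter)). With 4-fluorophenyl held constant, the other position also moves the number, as 2-hydroxyethoxy replaces chloro (a 2.8-fold lower number from compound 1 to compound 4 (0.45 log units; beyond the scatter)). No measurement on hand accounts for either shift. As far as these compounds go, whether other groups at the aromatic carbon would fall with 4-methylphenyl or with the other two remains open. So does the reading in this assay for a primary amine or a carboxylic acid in place of 2-hydroxyethoxy.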